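The source may hold more compounds than are shown below. What is called first, only, known or untested is meant among the compounds shown, and "the series" means these compounds.

Of the compounds shown here, three built on the shared core have been tested in a functional assay on PANC-1 cells (Homo sapiens) for inhibition, read by MTT assay, with a stated time of 72 h; a higher number here means a weaker inhibitor, a lower number a stronger inhibitor. Compound 1, `O=C(Nc1cccc2cccnc12)c1cccc(Br)n1`, gives > 10000 nM in this assay, and that figure is a limit of the assay rather than a number. Compound 2, `O=C(Nc1cccc2cccnc12)c1cccnn1`, likewise reaches only a limit in this assay, > 10000 nM. Among the measured compounds shown here, compound 3, `Cc1cnc(C(=O)Nc2cc(F)cc3cccnc23)cn1`, is the one compound with an actual number: in this assay compound 3 gives 2100 nM. Compound 3 therefore stands alone on the numeric scale, since the other two values sit at the limit of > 10000 nM in this assay, at which 2 of the 3 values shown sit.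

Compound 4, `COc1cc(NC(=O)c2cnc(C)cn2)c2ncccc2c1`, has not yet been measured. It differs from compound 3 in one place: methoxy in place of fluoro on an aromatic carbon. No pair of measured compounds differs by this kind of change, so there is no measured step to lean on, and no effect of the exchange can be read from the data shown. The expectation is that the move from compound 3 to compound 4 stays within the usual scatter, or at most drifts slightly toward weaker inhibition, with an expected step of a 1.3-fold higher number from compound 3 to compound 4 (0.12 log units; within the scatter). Compound 4 is accordingly estimated at 2800 nM in this assay, within a range from 800 nM to 9500 nM.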

Compound 4, half-maximal inhibitory concentration: 800 nM
For compound 4 the middle estimate is 3.5-fold (0.54 log units) above the measured one, and the stated range covers the measured number.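

Among the compounds shown here, putting methoxy in place of fluoro on this aromatic carbon gives a 2.6-fold lower number from compound 3 to compound 4 (0.42 log units; beyond the scatter) in this assay, the first step between two measured numbers in this set. Although modest, the step lies beyond the scatter, so this position, meta to a large group and para to a fused ring, can take a group of two heavy atoms in place of one while inhibition gets stronger rather than weaker. It also shows that a change at this single place on the shared core is enough to shift the read-out, with the rest of the molecule left as it stands.

The entering methoxy carries one hydrogen-bond acceptor where fluoro carries none, but a single pair cannot separate that difference from the added size or from anything else, and nothing measured here bears on the reason for the step. Open too, from the compounds shown here alone, is how an amine, a hydroxyl group or a longer chain such as ethoxy would fare at this position, and whether the same exchange would give a similar step on compounds with a different ring on the amide carbonyl.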